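The source may report more compounds than this note shows. Statements on the series, on what has been measured and on what is new or still open speak of the compounds shown alone.

Measured so far in a functional assay on Caco-2 cells (Homo sapiens), read by fluorescence, tested at 1 uM; on this read-out lower numbers stand for a stronger effect and higher numbers for a weaker effect at the one concentration tested:
- compound 1 `CC(C)CNC(=C\C(=O)/C=C/c1ccc(O)cc1)/C=C/c1ccc(O)cc1` gives 100%
- compound 2 `CC(=O)Oc1ccc(/C=C/C(=O)/C=C(/C=C/c2ccc(OC(C)=O)cc2)NCC(C)C)cc1` gives 102%
- compound 3 `COc1cc(/C=C/C(=O)/C=C(/C=C/c2ccc(O)c(OC)c2)NCC(C)C)ccc1O` gives 91%

On these three numbers compound 1 stands second highest. Its nearest neighbour is compound 2, whose value sits a couple of points higher, and the furthest is compound 3, whose value sits a handful of points lower; both gaps fall within the usual scatter of this assay, so the three compounds cannot be told apart on this read-out, and none of them can be called stronger or weaker than another. For the measured compounds named here, no single-change step between measured compounds is available to lean on.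

Compound 4 `O=C(/C=C(/C=C/c1ccc(O)cc1)NC1CCCCC1)/C=C/c1ccc(O)cc1` has not yet been measured. Compared with compound 1 it carries one change: cyclohexyl in place of isobutyl on an amine nitrogen. Read one bond further out, an isobutylamino becomes a cyclohexylamino. Since compounds 1, 2 and 3 all return values of about the same size in this assay whatever the rest of the molecule looks like, the step from compound 1 to compound 4 is expected to stay within the scatter, with no clear direction, which is what a number 2 percentage points lower from compound 1 to compound 4 (within the scatter) means. Compound 4 is therefore estimated at 98%, with a likely range from 85% to 110%.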

Compound 4, a percentage reported as activity, at one concentration (the size of the read-out at that concentration, not a potency): 97%
Compound 4: the middle estimate sits 1 percentage points above what was measured; the range from low to high includes it.
By their numbers in this assay, from the lowest: compounds 3, 4, 1 and 2 (each within the scatter of the next, the first and the last beyond it).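

In this assay, for the compounds shown here, replacing isobutyl with cyclohexyl on the amine nitrogen gives a number 3 percentage points lower from compound 1 to compound 4 (within the scatter), which provides the first direct comparison in which only this one group differs. An open branched carbon chain can therefore give way to a bigger six-membered non-aromatic ring of carbon only, with no difference that can be told from the scatter at the one concentration tested. Why the two compounds read alike cannot be said, as nothing available bears on that question.

Isobutyl and cyclohexyl are both made of carbon only and carry no hydrogen-bond donors or acceptors, so the compounds shown leave open whether a group with other atoms on this nitrogen, such as a longer chain ending in a carboxylic acid or a hydroxyethyl group, would read the same way, and a benzyl group, with its aromatic ring, is equally untested here. As far as these compounds go, with a single concentration and no potency value, it also remains open whether compound 1 and compound 4 would still look alike at other concentrations.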